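A few compounds are considered here, and "the series" means these few. Any claim that something is new, unique, unknown or untested is made for them only; others in the source may bear on it.

Measured compounds:
compound 1 `Cc1nc(S(C)(=O)=O)ccc1Oc1ncnc(OC2CCN(C(=O)OC(C)C)CC2)c1F`, 142 nM in a functional assay on isolated protein for inhibition of Glucose-dependent insulinotropic receptor (Rattus norvegicus), read by HTRF and cAMP accumulation; a higher number here means that more compound is needed for the effect, a lower number that less compound is needed
compound 2 `Cc1nc(S(C)(=O)=O)ccc1Oc1ncnc(OC2CCN(C(=O)OC3(C(F)(F)F)CCC3)CC2)c1F`, 63.3 nM
compound 3 `CCC(F)(F)C(=O)N1CCC(Oc2ncnc(Oc3ccc(S(C)(=O)=O)nc3C)c2F)CC1`, 69.2 nM

Compound 2 gives the lowest of the three numbers in this assay. Its nearest neighbour is compound 3, which sits within the scatter of it, as a 1.1-fold higher number from compound 2 to compound 3 (0.04 log units; within the scatter) shows; the furthest is compound 1, from which a 2.2-fold lower number from compound 1 to compound 2 (0.35 log units; beyond the scatter) separates it beyond the scatter. Compound 3 stands at a similar distance from compound 1, with a 2.1-fold lower number from compound 1 to compound 3 (0.31 log units; beyond the scatter).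

Compound 4 `CCc1cnc(C(=O)N2CCC(Oc3ncnc(Oc4ccc(S(C)(=O)=O)nc4C)c3F)CC2)nc1` is not yet measured. It differs from compound 2 in one place: a group of 8 heavy atoms (6 carbon, 2 nitrogen; one six-membered aromatic ring with 2 hetero atoms) in place of a group of 9 heavy atoms (5 carbon, 1 oxygen, 3 fluorine; one four-membered non-aromatic ring of carbon only), on a carbonyl carbon.

The step from compound 2 to compound 3 is the one that bears most directly on this change, since it also replaces the same group on a carbonyl carbon with a group lacking the four-membered ring, and it stayed within the scatter. Compound 3 and compound 2, however, both leave compound 1 behind by a modest margin. Going by the values given here, no measured step introduces an aromatic ring at this position, so a change in either direction beyond the scatter cannot be ruled out from these three compounds alone. Compound 4 is therefore expected to land near compound 2, with a 1.3-fold higher number from compound 2 to compound 4 (0.10 log units; within the scatter) as the estimated step. The estimate for compound 4 in this assay is 80 nM, in the range 30 nM to 250 nM.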

Compound 4, half-maximal effective concentration: 40.8 nM
Compound 4: middle estimate off by 2.0-fold (0.29 log units), on the high side, and the stated range covers the measured number.
By their numbers in this assay, from the lowest: compounds 4, 2 and 3 (each within the scatter of the next); then compound 1.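

The result shows that an aromatic ring is tolerated on the carbonyl carbon whose other neighbours are the amide-type nitrogen in a ring: in this assay, 5-ethylpyrimidin-2-yl gives a 1.6-fold lower number from compound 2 to compound 4 (0.19 log units; within the scatter) against the 1-(trifluoromethyl)cyclobutyl carbamate group and a 1.7-fold lower number from compound 3 to compound 4 (0.23 log units; within the scatter) against 1,1-difluoropropyl. Three quite different groups at this place, one joined through oxygen, one a fluorinated chain and one a pyrimidine, therefore give numbers that cannot be told apart in this assay. The pyrimidine also keeps the separation from the isopropoxy group, with a 3.5-fold lower number from compound 1 to compound 4 (0.54 log units; beyond the scatter) as the step, so compound 1 remains the only one of the four set apart from the others, and nothing measured here accounts for this.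

The compounds shown leave open whether the ring nitrogens or the ethyl group contribute anything, as they offer no phenyl or pyridine ring at this place and no pyrimidine carrying a hydrogen, a methoxy group or a longer chain in place of the ethyl. They also leave open whether any group on this carbonyl carbon can move the number beyond the scatter of compounds 2, 3 and 4.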